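The compounds below may be only part of what the source reports. "The series", "measured", "known", "first", "only" and "open" are said of these compounds alone.

Measured so far:
- compound 1 `C[C@H](Oc1ccc2ncc(/C=C/C(N)=O)c(C3CC3)c2c1)c1c(Cl)ccc(F)c1Cl`: > 5.5
- compound 2 `C[C@H](Oc1ccc(/C=C/C(=O)O)c(C2CC2)c1)c1c(Cl)ccc(F)c1Cl`: 3.6
- compound 3 `C[C@H](Oc1ccc2nc(OCCN)c(CCC(=O)O)c(C3CC3)c2c1)c1c(Cl)ccc(F)c1Cl`: 3.8

Three compounds of the series have numbers in a physicochemical assay for lipophilicity, using the shake flask method; a higher number here means a more lipophilic compound, a lower number a more polar compound. Compound 1 stands at the limit of > 5.5 in this assay, at which 1 of the 3 values shown sits, which is a limit of the assay and not a number. Of the two measured numbers, compound 3 gives 3.8, and compound 2 gives 3.6; the two lie within the usual scatter of each other, so no order between them can be read from this assay. Among the measured compounds shown here, no pair of measured compounds differs in one place only, so no measured step is available to lean on.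

Compound 4 `C[C@H](Oc1ccc2ncc(CCC(=O)O)c(C3CC3)c2c1)c1c(Cl)ccc(F)c1Cl` has not yet been measured in this assay. It differs from compound 3 in one place: hydrogen in place of 2-aminoethoxy on an aromatic carbon. For the step from compound 3 to compound 4, an upward move beyond the scatter is expected, that is a number 0.50 log units higher from compound 3 to compound 4 (beyond the scatter). Compound 4 is therefore expected to give about 4.3 in this assay, with a range from 3.6 to 5. A reported limit rather than a number is possible but considered unlikely.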

Compound 4, distribution coefficient: 4.1
The estimate for compound 4 lay 0.20 log units above the measured number, and the stated range covers the measured number.
By their numbers in this assay, from the lowest: compounds 2, 3 and 4 (each within the scatter of the next, the first and the last beyond it). At a limit, above all of these: compound 1.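

In this assay, hydrogen in place of 2-aminoethoxy on the aromatic carbon next to the ring nitrogen gives a number 0.30 log units higher from compound 3 to compound 4 (within the scatter), so this assay does not separate the two compounds at this position. Compound 1 gives > 5.5, which is a limit of the assay and not a number. The change on the neighbouring aromatic carbon, 2-carboxyethyl in place of 2-carbamoylethenyl, gives a number at least 1.40 log units lower from compound 1 to compound 4 (beyond the scatter), so this side chain, not the 2-aminoethoxy position, carries the only step beyond the scatter so far, and its size is known only as a bound: the limit of > 5.5 in this assay, at which 1 of the 4 values shown sits.

That step joins two differences in one group, the terminal amide against the carboxylic acid and the saturated chain against the unsaturated one, and a 2-carbamoylethyl group would be needed to part them. On these data alone, at the position next to the ring nitrogen, it remains open how a methoxy group or a longer chain ending in an amine would read in this assay.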